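The source may report more compounds than this note shows. Statements on the series, on what has been measured and on what is new or still open speak of the compounds shown alone.

Compounds measured so far:
compound 1 `CN(C)c1ccc(C2CC(c3ccccc3)=NN2C2=NC(=O)/C(=C3\C(=O)Nc4ccccc43)S2)cc1` — 45600 nM
compound 2 `CN(C)c1ccc(C2CC(c3ccccc3)=NN2C2=NC(=O)/C(=C3\C(=O)Nc4ccc(Br)cc43)S2)cc1` — 1290 nM

Within the data shown here, compound 2 holds the lowest of the two numbers in a functional assay on cells (Leukemia cell, Homo sapiens) for cytotoxicity, read by sulforhodamine B assay, with a stated time of 48 h; on this read-out lower numbers stand for stronger inhibition of growth and higher numbers for weaker inhibition of growth; the only neighbour is compound 1, whose value stands far higher. Among the measured compounds shown here, the one step measured so far, a 35-fold lower number from compound 1 to compound 2 (1.55 log units; beyond the scatter), came from a bromo replacing a hydrogen on an aromatic carbon and was large. Compound 3 `CN(C)c1ccc(C2CC(c3ccccc3)=NN2C2=NC(=O)/C(=C3\C(=O)Nc4ccc(Cl)cc43)S2)cc1` differs from compound 2 by chloro in place of bromo on an aromatic carbon, so the halogen is kept and only its identity changes. For the measured compounds named here, no measured step concerns this exchange directly, and the hydrogen-to-bromo step says only that a halogen at this position matters, not how chloro compares with bromo. Compound 3 is therefore expected to stay close to compound 2 in this assay, with a step of a 1.4-fold higher number from compound 2 to compound 3 (0.14 log units; within the scatter) that need not exceed the scatter. The estimated value for compound 3 is 1800 nM, within a range of 600 nM to 5500 nM.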

Compound 3, concentration for total growth inhibition: 3110 nM
The estimate for compound 3 lay 1.7-fold (0.24 log units) below the measured number; measured number inside the range.
By their numbers in this assay, from the lowest: compound 2; then compound 3; then compound 1.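

In this assay the identity of the halogen at this position matters and not only its presence: the change from bromo to chloro gives a 2.4-fold higher number from compound 2 to compound 3 (0.38 log units; beyond the scatter) and so separates the two halogens by a modest step. Chloro still stands well apart from hydrogen, with a 15-fold lower number from compound 1 to compound 3 (1.17 log units; beyond the scatter) as a large step, so among these three compounds the numbers rise from bromo through chloro to hydrogen. Nothing given here bears on why the two halogens differ.

The compounds shown leave open whether this order extends to fluoro or iodo at the same place. They also leave open whether a group that is not a halogen, such as methoxy or an amine, would stand nearer to bromo or to hydrogen.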